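The source may report more compounds than this note shows. Statements on the series, on what has been measured and on what is new or still open speak of the compounds shown alone.

The measured compounds:
compound 1, `COc1ccc2[nH]cc(Cc3nn4c(Cc5ccc(OC)c(OC)c5)nnc4s3)c2c1`, gives 4.11% in a functional assay on the whole organism (strain Wistar Albino) for inhibition, with Rattus norvegicus as the target, read by paw edema, with a stated time of 1 h, at a dose of 20 mg/kg; a lower number here means less inhibition, a higher number more inhibition at the dose given (going by the name of the read-out);
compound 2, `COc1ccc2[nH]c(C)c(Cc3nn4c(Cc5ccc(OC)c(OC)c5)nnc4s3)c2c1`, gives 10.5% in this assay;
compound 3, `COc1ccc2[nH]c(C)c(Cc3nn4c(-c5ccoc5C)nnc4s3)c2c1`, gives 19.7% in this assay.

Among these three numbers compound 1 stands lowest. Its nearest neighbour is compound 2, whose number lies within the scatter of it; compound 3 lies beyond the scatter, with the higher number. Among the compounds with values here, the only step between two compounds that differ in a single place, a number 6.4 percentage points higher from compound 1 to compound 2 (within the scatter), stays within the scatter.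

Compound 4, `COc1ccc(Cc2nnc3sc(Cc4c[nH]c5ccccc45)nn23)cc1OC`, has not yet been measured in this assay. Compared with compound 1 it differs in one place: hydrogen in place of methoxy on an aromatic carbon. Within the data shown here, no measured step shows a methoxy leaving the shared core in this way; the one measured single-point step, a number 6.4 percentage points higher from compound 1 to compound 2 (within the scatter), concerns a different change and did not move the number beyond the scatter. There is therefore no ground to expect a step beyond the scatter, and the expected change a number 0.9 percentage points higher from compound 1 to compound 4 (within the scatter) is small. Compound 4 is estimated to give 5% in this assay, within a range from 0% to 15%.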

Compound 4, a percentage reported as inhibition, in the whole organism at one dose (the size of the read-out at that dose, not a potency): 16.1%
For compound 4 the middle estimate is 11.1 percentage points below the measured one; the whole stated range lies below it.
By their numbers in this assay, from the lowest: compounds 1, 2, 4 and 3 (each within the scatter of the next, the first and the last beyond it).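

Replacing the methoxy with hydrogen on this aromatic carbon, in the six-membered ring of carbon only that is part of the fused system of two rings, gives a number 12 percentage points higher from compound 1 to compound 4 (beyond the scatter) in this assay at the dose given. This is the first single change shown here that goes beyond the scatter, so this position can affect the read-out, although the step is modest. It also shows that the methoxy at this position is not required for the inhibition seen with compound 4. No measurement on hand speaks to what lies behind this step.

The compounds shown leave open whether a different group here, such as a hydroxyl or an ethoxy, would give a number closer to compound 1 or to compound 4. They also leave open whether removing the methoxy would give a similar step in compound 2, which carries the added methyl.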